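Cyanophenyl in place of oxazole at the pyrimidine position

The source may hold more compounds than are shown below. What is called first, only, known or untested is meant among the compounds shown, and "the series" means these compounds.

Three compounds share one core. Compound 1 `Nc1nc(-c2ncco2)nc2sc(CN3CC=CCC3)cc12` gives 2960 nM in an assay on CHO-K1 cells for antagonist activity at adenosine receptor A1 (Homo sapiens), read by a beta-galactosidase reporter, with stated times of 15 min and 6 h; a higher number here means a weaker inhibitor, a lower number a stronger inhibitor. Compound 2 `Nc1nc(-c2cocn2)nc2sc(CN3CC=CC3)cc12` gives 3900 nM. Compound 3 `Nc1nc(-c2cocn2)nc2sc(CN3CC=CCC3)cc12` gives 2960 nM; it stands level with compound 1, the two together the lowest of the three numbers, with compound 2 the furthest away by a 1.3-fold lower number from compound 2 to compound 3 (0.12 log units; within the scatter). Compound 4 `N#Cc1ccc(-c2nc(N)c3cc(CN4CC=CCC4)sc3n2)cc1` differs from compound 3 by 4-cyanophenyl in place of 1,3-oxazol-4-yl on an aromatic carbon. Among the measured compounds shown here, only one measured step concerns the same position, no change at the digits printed from compound 1 to compound 3 (within the scatter), and it is an isomer swap of the oxazole, not an exchange of the ring type; the other step, at the amine side chain, was also small. For the measured compounds named here, no measured step therefore bears directly on the change to compound 4, and compound 4 is expected near 2500 nM, range 600 nM to 10000 nM. The expected step of a 1.2-fold lower number from compound 3 to compound 4 (0.07 log units; within the scatter) is estimated to stay inside the scatter.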

Compound 4, inhibition constant: 1630 nM
Compound 4: middle estimate off by 1.5-fold (0.19 log units), on the high side; measured number inside the range.
By their numbers in this assay, from the lowest: compounds 4, 1, 3 and 2 (each within the scatter of the next, the first and the last beyond it).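

In this assay, among the compounds shown here, a 1.8-fold lower number from compound 3 to compound 4 (0.26 log units; within the scatter) and a 1.8-fold lower number from compound 1 to compound 4 (0.26 log units; within the scatter) come with the first change of ring type at this position, where earlier only the oxazole isomers differed. A six-membered aromatic ring of carbon only, carrying a nitrile, thus takes the place of either oxazole without a step beyond the scatter. Nothing available here explains the result.

Still open, going by these compounds, is whether a plain phenyl, or a carboxylic acid or an amine in place of the nitrile, would stay in this range. Also open, on these data alone, is whether 4-cyanophenyl behaves alike with the five-membered ring side chain of compound 2.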